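Sulfonyl series: from methyl to trifluoromethyl

The compounds below may be only part of what the source reports. "The series", "measured", "known", "first", "only" and "open" are said of these compounds alone.

- compound 1 `CCCS(=O)(=O)Oc1ccc2c3c(c(=O)oc2c1)CCCCCC3` gives 10000 nM
- compound 2 `Cc1ccc(S(=O)(=O)Oc2ccc3c4c(c(=O)oc3c2)CCCCCC4)cc1` gives 40700 nM

Among the compounds with values here, in a functional assay on RAW264.7 cells (Mus musculus) for inhibition, read by Griess assay, with a stated time of 24 h (on this read-out lower numbers stand for stronger inhibition and higher numbers for weaker inhibition), compound 2 stands highest at 40700 nM with compound 1 as its only neighbour. The next change leads to compound 3 `O=c1oc2cc(OS(=O)(=O)c3ccc(C(F)(F)F)cc3)ccc2c2c1CCCCCC2` with trifluoromethyl in place of methyl on an aromatic carbon as the difference, trifluoromethyl in place of methyl on an aromatic carbon. Within the data shown here, the one measured step, a 4.1-fold higher number from compound 1 to compound 2 (0.61 log units; beyond the scatter) with 4-methylphenyl in place of propyl on a sulfonyl sulfur, was modest. Among the measured compounds shown here, that step replaced the whole group on sulfur, and no measured step covers a change on the aromatic ring, so the data fix no direction here. No shift beyond the scatter is expected in this assay for this change. On these data alone, the expected step is a 1.1-fold lower number from compound 2 to compound 3 (0.05 log units; within the scatter) and either direction stays open. Compound 3 is estimated at 36000 nM with 14000 nM to 90000 nM as its expected range.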

Compound 3, half-maximal inhibitory concentration: 75300 nM
The estimate for compound 3 lay 2.1-fold (0.32 log units) below the measured number, and the stated range covers the measured number.
By their numbers in this assay, from the lowest: compound 1; then compounds 2 and 3 (each within the scatter of the next).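

In this assay, within the data shown here, this is the first reading of a change on the aromatic ring: trifluoromethyl in place of methyl, para to a large group, gives a 1.9-fold higher number from compound 2 to compound 3 (0.27 log units; within the scatter), so this exchange does not separate the two compounds. Replacing propyl on the sulfonyl sulfur with 4-(trifluoromethyl)phenyl gives a 7.5-fold higher number from compound 1 to compound 3 (0.88 log units; beyond the scatter), so compounds 2 and 3, the two with a substituted phenyl on sulfur, both stand beyond the scatter from compound 1. No evidence on the cause of these numbers is at hand.

On these data alone, whether a methoxy group or an amine on the same aromatic carbon would read apart from methyl stays open. As far as these compounds go, it is also open whether a chain longer than propyl on the sulfonyl sulfur would give a lower number than compound 1.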